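The compounds below may be only part of what the source reports. "The series", "measured", "known", "first", "only" and "open" are said of these compounds alone.

Measured compounds:
- Compound 1 `COc1ccc(F)cc1CNCCCNc1ccnc2cc(Cc3ccc(F)cc3Cl)ccc12` — 23 10^-6 cm/s
- Compound 2 `COc1ccccc1Oc1ccc2c(NCCCNCc3ccco3)ccnc2c1` — 317 10^-6 cm/s
- Compound 3 `Fc1ccc(Cc2ccc3c(NCCCNCc4ccco4)ccnc3c2)c(Cl)c1` — 23 10^-6 cm/s

In an ADME assay for permeability, using PAMPA, with a stated time of 30 min, at pH 7.4 (on this read-out lower numbers stand for lower permeability and higher numbers for higher permeability), compound 1 gives 23 10^-6 cm/s. It stands level with compound 3, and together they hold the lowest of the three numbers: no change at the digits printed from compound 1 to compound 3 (within the scatter). Within the data shown here, the only large change seen is a 14-fold lower number from compound 2 to compound 3 (1.14 log units; beyond the scatter), where a 2-chloro-4-fluorobenzyl group on an aromatic carbon of the shared core replaces a 2-methoxyphenoxy group.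

Compound 4 `COc1ccc(F)cc1CNCCCNc1ccnc2cc(-c3ccccc3)ccc12` is not yet measured. It differs from compound 1 in one place: phenyl in place of 2-chloro-4-fluorobenzyl on an aromatic carbon.

Among the measured compounds shown here, no measured step replaces a 2-chloro-4-fluorobenzyl group with a phenyl group, so the step from compound 1 to compound 4 has no direct precedent. The nearest hint is that the group at this aromatic carbon matters a great deal, as shown by a 14-fold lower number from compound 2 to compound 3 (1.14 log units; beyond the scatter), while the change at the chain carbon, no change at the digits printed from compound 1 to compound 3 (within the scatter), did nothing beyond the scatter. Phenyl is a smaller group than 2-chloro-4-fluorobenzyl, and the direction of its effect in this assay is uncertain; a moderate rise is expected, at a 2.6-fold higher number from compound 1 to compound 4 (0.42 log units; beyond the scatter). Compound 4 is therefore estimated at 60 10^-6 cm/s, with a range from 15 10^-6 cm/s to 250 10^-6 cm/s.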

Compound 4, apparent permeability: 237 10^-6 cm/s
The estimate for compound 4 lay 4.0-fold (0.60 log units) below the measured number, and the stated range covers the measured number.
By their numbers in this assay, from the lowest: compounds 1 and 3 (each within the scatter of the next); then compounds 4 and 2 (each within the scatter of the next).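

In this assay, putting phenyl in place of 2-chloro-4-fluorobenzyl on this aromatic carbon gives a 10-fold higher number from compound 1 to compound 4 (1.01 log units; beyond the scatter). The earlier large step at this carbon, a 14-fold lower number from compound 2 to compound 3 (1.14 log units; beyond the scatter), had 2-chloro-4-fluorobenzyl entering in compounds with a furan-2-yl group on the chain, whereas here it leaves in compounds with a 5-fluoro-2-methoxyphenyl group there, so in both pairs the compound carrying 2-chloro-4-fluorobenzyl has the lower number. Nothing measured here gives a reason for this difference.

The change removes the chlorine, the fluorine and the extra carbon together, so the compounds shown cannot tell which of these parts goes with the lower number. Going by these compounds, a plain benzyl group or a 2-chlorophenyl group at this carbon would separate them, and how an amine there would read remains open.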